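A Triazole Swap on a Urea with Only Limits Known

This account rests on a few compounds, and the source may have more. Where it says the series, first, only, none or still open, it means among the compounds named here.

Two compounds with a shared urea core are measured in a functional assay on a cell-free system (plasma) with sterol O-acyltransferase, Soat (Rattus norvegicus) as the target; on this read-out higher numbers stand for an effect only at larger amounts of compound and lower numbers for an effect already at smaller amounts. Compound 1 `O=C(Nc1c(F)cc(F)cc1F)N(Cc1ccc(-c2ccccn2)cc1)C1CCCCCC1` reaches only the limit of the assay, giving > 1 mg/kg. Compound 2 `Cc1cc(C)c(NC(=O)N(Cc2ccc(-c3ccccn3)cc2)C2CCCCCC2)c(C)c1` likewise stops at the limit, giving > 1 mg/kg. Among the compounds with values here, the one step between them, a step that the two limits leave unreadable from compound 1 to compound 2, therefore cannot be read. Compound 2 thus stands at the limit of > 1 mg/kg in this assay, at which 2 of the 2 values shown sit, with no number of its own in this assay.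

Compound 3 `Cc1cc(C)c(NC(=O)N(Cc2ccc(-n3nccn3)cc2)C2CCCCCC2)c(C)c1` differs from compound 2 in a single place: 2H-1,2,3-triazol-2-yl in place of pyridin-2-yl on an aromatic carbon. Within the data shown here, no measured step touches this part of the molecule; the only step known is unreadable and concerns a different ring. Nothing therefore points to a direction, and no size of step beyond the usual scatter can be argued. The step that the limit leaves unreadable from compound 2 to compound 3 is expected to show no clear change. The estimate for compound 3 in this assay is 2 mg/kg, within 0.5 mg/kg to 8 mg/kg, and a second limit rather than a number is the more likely outcome.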

Compound 3, dose for half-maximal effect: > 1 mg/kg
Compound 3: only a limit was reported; the forecaster's own chance of this, stated with the estimate: 65%; the middle value does not contradict the limit.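

In this assay, within the data shown here, compound 3 gives only a limit of the assay, > 1 mg/kg, and compound 2 also gives only a limit, so no step between compound 2 and compound 3 can be read. Left open is whether 2H-1,2,3-triazol-2-yl in place of pyridin-2-yl changes the dose needed, and what actual value compound 1, compound 2 or compound 3 has.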